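The source may report more compounds than this note shows. Statements on the series, on what has been measured and on what is new or still open speak of the compounds shown alone.

Working notes on the aminothiophene series.

Three compounds have been run so far in a functional assay on CHO cells with adenosine receptor A1 (Homo sapiens) as the target, read by cAMP accumulation and immunoassay, with a stated time of 6 min, tested at 0.1 uM; on this read-out higher numbers stand for a weaker effect at the one concentration tested and lower numbers for a stronger effect. Compound 1 `Nc1scc(CN2CCN(c3ccc(OC(F)(F)F)cc3)CC2)c1C(=O)c1ccc(Cl)cc1` gives -13%. Compound 2 `Nc1scc(CN2CCN(c3cccc(F)c3)CC2)c1C(=O)c1ccc(Cl)cc1` gives -37%. Compound 3 `Nc1scc(CN2CCN(c3ccccc3F)CC2)c1C(=O)c1ccc(Cl)cc1` gives -1%, which places compound 3 highest of the three numbers; its nearest neighbour is compound 1, and compound 2 lies furthest from it.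

The measured steps all sit on the amine nitrogen in the ring. The change a number 24 percentage points lower from compound 1 to compound 2 (beyond the scatter). The change a number 12 percentage points higher from compound 1 to compound 3 (beyond the scatter). The change a number 36 percentage points higher from compound 2 to compound 3 (beyond the scatter).

Compound 4 `Nc1scc(CN2CCN(c3cccc(Cl)c3)CC2)c1C(=O)c1ccc(Cl)cc1` is next. It differs from compound 3 as follows: 3-chlorophenyl in place of 2-fluorophenyl on an amine nitrogen in a ring. Among the measured compounds shown here, the step that bears most directly on this is the one from compound 2 to compound 3, which exchanged 3-fluorophenyl for 2-fluorophenyl and was large; compound 4 returns to a 3-substituted phenyl, with chlorine in place of fluorine, so the expectation is a step back in the direction of compound 2. The step from compound 1 to compound 2 also points to a lower number for a 3-substituted phenyl.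

Compound 4 is therefore expected to read -30% in this assay, within a range of -55% to 0%. This estimate means an expected step of a number 29 percentage points lower from compound 3 to compound 4 (beyond the scatter), with the direction taken from compound 2 and compound 3.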

Compound 4, a percentage reported as activity, at one concentration (the size of the read-out at that concentration, not a potency): -20%
Beside the measured number, compound 4's estimate is 10 percentage points below it; the measured number falls inside the stated range.
By their numbers in this assay, from the lowest: compound 2; then compounds 4 and 1 (each within the scatter of the next); then compound 3.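

The 3-chlorophenyl group in this assay gives a number 19 percentage points lower from compound 3 to compound 4 (beyond the scatter) and so joins 3-fluorophenyl in reading lower than 2-fluorophenyl, although this step changes both the halogen and where it sits on the phenyl ring. The halogen alone also counts at this position, since chloro in place of fluoro on an aromatic carbon gives a number 17 percentage points higher from compound 2 to compound 4 (beyond the scatter) and the number moves back towards that of the 2-fluorophenyl compound without reaching it. By contrast, 3-chlorophenyl in place of 4-(trifluoromethoxy)phenyl gives a number 7 percentage points lower from compound 1 to compound 4 (within the scatter) and so separates these two groups by nothing that can be read here, while no supporting data offer a cause for any of these steps.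

The compounds shown leave open how much of the 2-fluorophenyl reading belongs to the fluorine's place and how much to the halogen, a question that 2-chlorophenyl would address directly. They also leave open whether the trend with halogens extends to a 3-methoxyphenyl group or to a nitrile or an amine carried on the phenyl ring.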